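This account rests on a few compounds, and the source may have more. Where it says the series, first, only, none or still open, it means among the compounds named here.

In a functional assay on HeLa cells (Homo sapiens) for cytotoxicity, read by MTT assay, with a stated time of 24 h (a lower number here means a stronger inhibitor, a higher number a weaker inhibitor), three compounds with related cores have been measured so far. Compound 1 `Nc1ccc2sc(NC(=S)NC(=O)c3ccc([N+](=O)[O-])cc3)nc2c1` gives 63100 nM. Compound 3 `Nc1ccc2sc(NC(=S)NC(=O)N3CCOCC3)nc2c1` gives 45300 nM. The difference between the cores of compound 1 and compound 3 is not broken down here. Compound 2 `O=C(NC(=S)Nc1nc2cc(Br)ccc2s1)N1CCOCC1` gives 38900 nM. Compound 2 differs from compound 3 in one place only, (bromo in place of amino on an aromatic carbon), and that change made a 1.2-fold lower number from compound 3 to compound 2 (0.07 log units; within the scatter). All three numbers lie within the usual scatter of one another, so none of them can be set apart from the rest on this evidence.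

Compound 4 `O=C(NC(=S)Nc1nc2cc(Br)ccc2s1)c1ccc([N+](=O)[O-])cc1` has not yet been measured. It differs from compound 1 by bromo in place of amino on an aromatic carbon. Among the compounds with values here, this is the same change as the one seen between compound 3 and compound 2, made at a place described in the same words. Because a 1.2-fold lower number from compound 3 to compound 2 (0.07 log units; within the scatter) stayed within the scatter, a step of similar size is expected here: a 1.2-fold lower number from compound 1 to compound 4 (0.08 log units; within the scatter). Compound 4 is therefore estimated at 52000 nM, with a likely range from 25000 nM to 110000 nM.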

Compound 4, half-maximal inhibitory concentration: 56500 nM
Compound 4: middle estimate off by 1.1-fold (0.04 log units), on the low side, and the stated range covers the measured number.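

In this assay, bromo in place of amino gave a 1.1-fold lower number from compound 1 to compound 4 (0.05 log units; within the scatter). Set beside the earlier case, the same change gives steps that cannot be told apart on the two cores: the same change on two cores in this assay, a 1.2-fold lower number (0.07 log units; within the scatter) from compound 3 to compound 2 and a 1.1-fold lower number (0.05 log units; within the scatter) from compound 1 to compound 4, 1.0-fold (0.02 log units) apart, within the scatter of two such steps. This shows that on these two cores the swap leaves the number within the usual scatter, so the small step carried over from one core to the other, but it does not show that the swap has any real effect, and two cores say nothing about how it would behave on a third.

Among the compounds shown, only amino and bromo appear at this aromatic carbon, so it remains open whether another group there, such as a methoxy group or a carboxylic acid, would give a step beyond the scatter. On these data alone, it also remains open whether the same swap stays this small on a compound with a much lower number in this assay, since all the numbers here lie close together.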